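The compounds below may be only part of what the source reports. "The series", "measured", "known", "first", "only" and "open" are said of these compounds alone.

Within the data shown here, in a functional assay on A2780 cells (Homo sapiens) for cytotoxicity (a lower number here means a stronger inhibitor, a higher number a weaker inhibitor), compound 1 `CCc1cnc(CSc2cnc(NC(C)=O)s2)o1` gives 1400 nM and holds the higher of the two numbers so far. Among the measured compounds shown here, compound 2 `CC(=O)Nc1ncc(SCc2ncc(C(C)(C)C)o2)s1` gives 50 nM and the one measured step is large: a 28-fold lower number from compound 1 to compound 2 (1.45 log units; beyond the scatter) (tert-butyl in place of ethyl on an aromatic carbon). Compound 3 `CCc1cnc(CSc2cnc(NC(=O)C(C)C)s2)o1` departs from compound 1 at a different place: isopropyl in place of methyl on a carbonyl carbon with isopropyl in place of methyl on a carbonyl carbon. For the measured compounds named here, no measured step tests that place, so the larger step offers only a loose guide to direction, and a much smaller drop is expected. The estimated step is a 1.8-fold lower number from compound 1 to compound 3 (0.24 log units; within the scatter) and remains uncertain. For compound 3 the estimated value is 800 nM (expected range 200 nM to 3000 nM).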

Compound 3, half-maximal inhibitory concentration: 200 nM
Estimate against measurement, compound 3: 4.0-fold (0.60 log units) above, and the stated range covers the measured number.
By their numbers in this assay, from the lowest: compound 2; then compound 3; then compound 1.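

With isopropyl in place of methyl on a carbonyl carbon, this assay shows a 7.0-fold lower number from compound 1 to compound 3 (0.85 log units; beyond the scatter). The number therefore responds to the group on the carbonyl carbon whose other neighbour is the amide-type nitrogen, and not only to the group on the aromatic carbon changed in compound 2. No evidence is available that accounts for this step. Going by these compounds, whether a longer chain, a tert-butyl or an amine on that carbonyl carbon would lower the number further remains open. Also open, on these data alone, is how the isopropyl and tert-butyl changes behave together in one compound.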